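Shortening the Acyl Chain of a Sub-Nanomolar Pair

The source may hold more compounds than are shown below. What is called first, only, known or untested is meant among the compounds shown, and "the series" means these compounds.

Measured compounds:
compound 1 `CCCCCCCC(=O)Nc1nnc(-c2cc(I)c(O)c(OC)c2)s1`: 0.33 nM
compound 2 `CCCCCCCCC(=O)Nc1nnc(-c2cc(I)c(O)c(OC)c2)s1`: 0.34 nM

In an in vitro assay on HEK-293T cells for antagonist activity at transient receptor potential cation channel subfamily V member 1 (Rattus norvegicus), read by fluorescence and calcium flux, with a stated time of 30 min (on this read-out higher numbers stand for weaker inhibition and lower numbers for stronger inhibition), compound 1 gives 0.33 nM and compound 2 gives 0.34 nM. The step between them, a 1.0-fold higher number from compound 1 to compound 2 (0.01 log units; within the scatter), is within the scatter, so compound 2 holds the highest number of the two only nominally; the two values cannot be told apart.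

Compound 3 `CCCCCCC(=O)Nc1nnc(-c2cc(I)c(O)c(OC)c2)s1` differs from compound 2 by hydrogen in place of ethyl on a saturated chain carbon, six bonds along the chain from a carbonyl carbon. For the measured compounds named here, the only measured step that bears on chain length is a 1.0-fold higher number from compound 1 to compound 2 (0.01 log units; within the scatter), which added one carbon at the chain end and changed nothing beyond the scatter. Going by the values given here, the present change removes two carbons, running the other way and further than any measured pair covers, so the single step is a weak guide. Compound 3 is therefore expected to stay close to compound 2, with some room for a modest loss, giving an expected step of a 1.5-fold higher number from compound 2 to compound 3 (0.17 log units; within the scatter). The estimate for compound 3 in this assay is 0.5 nM, with a range from 0.2 nM to 1.5 nM.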

Compound 3, half-maximal inhibitory concentration: 6.07 nM
Compound 3: the middle estimate sits 12-fold (1.08 log units) below what was measured; the measured number lies above the stated range.
By their numbers in this assay, from the lowest: compounds 1 and 2 (each within the scatter of the next); then compound 3.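

Hydrogen in place of ethyl, on the saturated chain carbon six bonds along the chain from a carbonyl carbon, gives an 18-fold higher number from compound 2 to compound 3 (1.25 log units; beyond the scatter) in this assay, and hydrogen in place of methyl at that same carbon gives an 18-fold higher number from compound 1 to compound 3 (1.26 log units; beyond the scatter). The chain is therefore not indifferent to its length, as a 1.0-fold higher number from compound 1 to compound 2 (0.01 log units; within the scatter) alone might have suggested. Among these compounds, inhibition is held with the two longer chains and clearly weakens with the shortest, so a single methyl at this carbon separates compound 1 from compound 3.

Still open, on these data alone, is whether a longer chain than that of compound 2 holds the same strength, whether a shorter chain weakens further, and how an amine or a carboxylic acid at the chain end would read. Nothing shown gives a reason for the sharp step at this carbon.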